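Ether series: cytotoxicity limits and an expected value

The source may hold more compounds than are shown below. What is called first, only, known or untested is meant among the compounds shown, and "the series" means these compounds.

Measured so far:
compound 1 `COc1cc(OC)c2c(c1)C(C(O)c1ccc(O)cc1)OC2=O` — limit, > 40000 nM
compound 2 `C=CCCOc1ccc(C(O)C2OC(=O)c3c(OC)cc(OC)cc32)cc1` — limit, > 40000 nM
compound 3 `COc1cc(OC)c2c(c1)C(C(O)c1ccc(OCc3ccc(OC(F)(F)F)cc3)cc1)OC2=O` — limit, > 40000 nM

In an ADME assay on RAW264.7 cells (Mus musculus) for cytotoxicity, read by MTT assay, with a stated time of 24 h, in the presence of a further agent that is not named here (a lower number here means a stronger inhibitor, a higher number a weaker inhibitor), compound 1 returns only a limit of the assay, not a number. The same holds for every value recorded, since (the limit of > 40000 nM in this assay, at which 3 of the 3 values shown sit). The step that the two limits leave unreadable from compound 1 to compound 2 is therefore unreadable, as is a step that the two limits leave unreadable from compound 2 to compound 3. Compound 4 `COc1cc(OC)c2c(c1)C(C(O)c1ccc(OCc3ccc(OC(F)F)cc3)cc1)OC2=O` differs from compound 1 by 4-(difluoromethoxy)benzyl in place of hydrogen on an oxygen on an aromatic ring. The two measured steps bear on this change only as far as they show that added ether groups on that oxygen left the read-out at the limit. Compound 4 is accordingly expected to stay at the limit as well, with an estimated value of 60000 nM in a range from 30000 nM to 200000 nM. The expected step that the limit leaves unreadable from compound 1 to compound 4 is estimated to be none that this assay can read.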

Compound 4, half-maximal inhibitory concentration: > 40000 nM
Compound 4: a limit, no number (the forecaster's own chance of this, stated with the estimate: 85%); the middle value is on the limit's open side.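

Compound 4 gives > 40000 nM, a limit and not a number, so its steps from compound 1, compound 2 and compound 3 cannot be read: the limit of > 40000 nM in this assay, at which 4 of the 4 values shown sit.

The compounds shown leave open whether any ether on that oxygen would return a number in this assay.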